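The compounds below may be only part of what the source reports. "The series", "measured", "known", "first", "only" and "open" are said of these compounds alone.

In an assay on isolated protein for inhibition of Calpain-1 catalytic subunit (Homo sapiens) (on this read-out higher numbers stand for weaker inhibition and lower numbers for stronger inhibition), the three measured compounds share one core and differ only in the group on an aromatic carbon. Compound 1 `NC(=O)c1cn(-c2ccc(O)cc2Cl)c2cc(-n3cccn3)ccc2c1=O` gives 600 nM. Compound 2 `NC(=O)c1cn(-c2ccc(O)cc2Cl)c2cc(-c3ccncc3Cl)ccc2c1=O` gives 2000 nM, and compound 3 `NC(=O)c1cn(-c2ccc(O)cc2Cl)c2cc(-c3cccnn3)ccc2c1=O` gives 2000 nM. Compound 3 stands level with compound 2, the two together at the highest numbers of the three; the steps of a 3.3-fold higher number from compound 1 to compound 2 (0.52 log units; beyond the scatter) and a 3.3-fold higher number from compound 1 to compound 3 (0.52 log units; beyond the scatter) are alike in size and direction. Compound 4 `NC(=O)c1cn(-c2ccc(O)cc2Cl)c2cc(-c3ccnc(F)c3)ccc2c1=O` is not yet measured. It differs from compound 3 by 2-fluoropyridin-4-yl in place of pyridazin-3-yl on an aromatic carbon. Going by the values given here, the only measured exchange of one six-membered heteroaryl ring for another at this carbon, no change at the digits printed from compound 2 to compound 3 (within the scatter), stayed within the scatter, and compound 4 carries a halogen-bearing pyridinyl group as compound 2 does. A step of no more than the scatter is therefore expected, a 1.3-fold lower number from compound 3 to compound 4 (0.10 log units; within the scatter). Compound 4 is expected to give about 1600 nM in this assay, within a range from 600 nM to 4500 nM.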

Compound 4, half-maximal inhibitory concentration: 30000 nM
The estimate for compound 4 lay 19-fold (1.27 log units) below the measured number; the whole stated range lies below it.
By their numbers in this assay, from the lowest: compound 1; then compounds 2 and 3 (each within the scatter of the next); then compound 4.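

In this assay, going by these compounds alone, this aromatic carbon proved far less forgiving of exchanges among six-membered heteroaryl rings than the earlier compounds suggested: two such rings sit level, yet 2-fluoropyridin-4-yl departs widely from both (a 15-fold higher number from compound 3 to compound 4 (1.18 log units; beyond the scatter); a 15-fold higher number from compound 2 to compound 4 (1.18 log units; beyond the scatter)). Carrying a halogen on a pyridinyl ring therefore does not by itself set the level here, as 3-chloropyridin-4-yl and 2-fluoropyridin-4-yl stand far apart, and the distance from 1H-pyrazol-1-yl is now much wider (a 50-fold higher number from compound 1 to compound 4 (1.70 log units; beyond the scatter)). Nothing measured here gives a reason for this loss.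

Going by these compounds, what remains open is whether the loss follows the fluorine or the pyridinyl ring that carries it. A plain pyridin-4-yl, or an amine or a methoxy group in place of that fluorine, would help to separate the two.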